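From Epoxide Chain to Acetyl on the Shared Core

A few compounds are considered here, and "the series" means these few. Any claim that something is new, unique, unknown or untested is made for them only; others in the source may bear on it.

Of the compounds shown here, three on one core have been measured in an assay on isolated protein for binding affinity to leukotriene B4 receptor 1 (Homo sapiens), tested at 1 uM; on this read-out higher numbers stand for more inhibition at the one concentration tested (going by the name of the read-out) and lower numbers for less inhibition. Compound 1 `CC(=O)c1ccc(OCCCCC#N)cc1O` carries hydrogen at the position of interest and in this assay compound 1 gives 0%. Compound 2 `CCc1cc(C(C)=O)c(O)cc1OCCCCC#N` carries ethyl there and in this assay compound 2 gives 57%. Compound 3 `CC(=O)c1cc(CC2CO2)c(OCCCCC#N)cc1O` carries (oxiran-2-yl)methyl there and in this assay compound 3 gives 24%, the second highest of the three numbers, with a number 24 percentage points higher from compound 1 to compound 3 (beyond the scatter) and a number 33 percentage points lower from compound 2 to compound 3 (beyond the scatter).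

Compound 4 `CC(=O)c1cc(C(C)=O)c(OCCCCC#N)cc1O` differs from compound 3 by one change, (acetyl in place of (oxiran-2-yl)methyl on an aromatic carbon), on the aromatic carbon ortho to the 4-cyanobutoxy group, meta to the acetyl group and para to the hydroxy group.

Going by the values given here, two steps bear on this. The step of a number 57 percentage points higher from compound 1 to compound 2 (beyond the scatter) shows that a small group with no ring helps strongly, while a number 33 percentage points lower from compound 2 to compound 3 (beyond the scatter) shows that the ring-bearing chain loses much of that gain. Acetyl, like ethyl, brings no ring, so a moderate rise is expected, a number 14 percentage points higher from compound 3 to compound 4 (beyond the scatter). Compound 4 is therefore estimated at 38%, expected to fall between 10% and 65%.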

Compound 4, a percentage reported as inhibition, at one concentration (the size of the read-out at that concentration, not a potency): 0%
Estimate against measurement, compound 4: 38 percentage points above; measured number outside the range, below it.
By their numbers in this assay, from the lowest: compounds 1 and 4 (each within the scatter of the next); then compound 3; then compound 2.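

In this assay, acetyl in place of the (oxiran-2-yl)methyl group gives a number 24 percentage points lower from compound 3 to compound 4 (beyond the scatter), so removing the three-membered ring does not by itself bring a gain at this position. Ethyl and acetyl both carry no ring, yet acetyl in place of ethyl gives a number 57 percentage points lower from compound 2 to compound 4 (beyond the scatter), which shows that the lack of a ring cannot be what decides the read-out here. Acetyl in place of hydrogen gives no change at the digits printed from compound 1 to compound 4 (within the scatter), so at this position the two cannot be told apart on this single-concentration read-out.

Nothing measured here explains why ethyl and acetyl end up so far apart. As far as these compounds go, whether a longer chain such as propyl, an amine or a carboxylic acid on this aromatic carbon would sit nearer to ethyl or to acetyl remains open.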